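Compound 1 to compound 4: a ring turned aromatic

The source may hold more compounds than are shown below. What is called first, only, known or untested is meant among the compounds shown, and "the series" means these compounds.

Compound 1 (`O=c1cc(Cc2c(F)cccc2F)nc(N2CCCC2)[nH]1`) is followed here in an ADME assay on MT4 cells (Homo sapiens) for cytotoxicity, read by MTT assay, with a stated time of 4 days; on this read-out higher numbers stand for lower toxicity in this test and lower numbers for higher toxicity in this test. Compound 1 gives > 86000 nM, which is a limit and not a number. Compound 2 (`O=c1cc(Cc2c(F)cccc2N2CCCC2)nc(N2CCCC2)[nH]1`) gives > 73000 nM, also a limit. Compound 3 (`O=c1cc(Cc2c(F)cccc2F)nc(N2CCC3(CC2)OCCO3)[nH]1`) gives > 69000 nM, again a limit. All three values are therefore limits, and compound 1 holds no exact place among them.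

Compound 4 (`O=c1cc(Cc2c(F)cccc2F)nc(-n2cccc2)[nH]1`) differs from compound 1 at one place: 1H-pyrrol-1-yl in place of pyrrolidin-1-yl on an aromatic carbon. In words, 1H-pyrrol-1-yl stands in place of pyrrolidin-1-yl on an aromatic carbon, between two ring nitrogen atoms.

Among the compounds with values here, only one measured step bears on this, and it changes another place on the core: a step that the two limits leave unreadable from compound 1 to compound 2. It offers no size to carry over. Because compound 1 stands at > 86000 nM, a limit, no step beyond the usual scatter is expected in this assay, and no direction is favoured. The expected result of the change is an at least 1.0-fold lower number from compound 1 to compound 4 (0.03 log units; that floor lies within the scatter), and a further limit would not surprise. The estimate for compound 4 is 80000 nM, with an expected range from 25000 nM to 120000 nM.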

Compound 4, half-maximal cytotoxic concentration: > 87000 nM
Compound 4: no number, only a limit (the forecaster's own chance of this, stated with the estimate: 70%); middle value at least 1.0-fold (0.03 log units) from the limit.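

Compound 1 and compound 4 are both recorded only as limits in this assay, and the step between them cannot be read. The compounds shown leave open where the true value of any of them lies in this assay, and whether 1H-pyrrol-1-yl and pyrrolidin-1-yl differ at all on this read-out.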